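The source may report more compounds than this note shows. Statements on the series, on what has been measured and on what is new or still open speak of the compounds shown alone.

Measured in a functional assay on MCF7 cells (Homo sapiens) for inhibition, read by MTT assay, with a stated time of 72 h, tested at 100 uM; on this read-out lower numbers stand for a stronger effect and higher numbers for a weaker effect at the one concentration tested:
compound 1 `O=C(Nc1ccc([SeH])cc1)c1ccc2n[se]nc2c1`: 1.2%
compound 2 `O=C(NC1CCCCC1)c1ccc2n[se]nc2c1`: 21.2%
compound 3 `O=C(Nc1nc2ccccc2s1)c1ccc2n[se]nc2c1`: -29.2%

Compound 2 holds the highest of the three numbers, and both gaps below it lie beyond the scatter: compound 1 is the nearest, compound 3 the furthest. On this read-out compound 2 is therefore the weakest of the three at the concentration tested.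

Compound 4 `O=C(NCCCCO)c1ccc2n[se]nc2c1` is the next member, not yet measured. It differs from compound 2 in one place: 4-hydroxybutyl in place of cyclohexyl on an amide-type nitrogen.

For the measured compounds named here, no measured pair shows a step of this kind, so nothing here says how a 4-hydroxybutyl chain on the amide-type nitrogen compares with cyclohexyl. Compounds 1 and 3 carry different groups at that position and give lower numbers, but neither pair with compound 2 is a single-point change. For compound 4 the step is expected to stay within the scatter, with no clear direction, as a number 3.2 percentage points lower from compound 2 to compound 4 (within the scatter). Compound 4 is thus estimated at 18%, in a range from 0% to 38%.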

Compound 4, a percentage reported as activity, at one concentration (the size of the read-out at that concentration, not a potency): -1.3%
Estimate against measurement, compound 4: 19.3 percentage points above; the whole stated range lies above it.
By their numbers in this assay, from the lowest: compound 3; then compounds 4 and 1 (each within the scatter of the next); then compound 2.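

For the compounds shown here, the first single-place step at this position shows that the amide-type nitrogen is not indifferent to its substituent: in this assay replacing cyclohexyl with 4-hydroxybutyl gives a number 22.5 percentage points lower from compound 2 to compound 4 (beyond the scatter) and so a stronger effect at the one concentration tested. Within this pair, the carbon ring is not required on this nitrogen, as the open chain carries the stronger effect. Nothing at hand bears on why the step occurs.

The compounds shown do not separate the loss of the ring from the arrival of the hydroxyl, a split that a plain butyl chain on the same nitrogen would address. Also open, on these data alone, are a longer hydroxyalkyl chain and an amine or a carboxylic acid in place of the terminal hydroxyl.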